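The source may hold more compounds than are shown below. What is called first, only, known or untested is meant among the compounds shown, and "the series" means these compounds.

In a functional assay (aorta) with Rattus norvegicus as the target (on this read-out lower numbers stand for stronger inhibition and higher numbers for weaker inhibition), three compounds built on one shared core have been measured. Compound 1 (`CC1(C)Oc2ccc(C#N)cc2[C@@H](/N=C(\NC#N)Nc2cccc(Cl)c2)[C@@H]1O`), which carries a chlorophenyl group, gives 600 nM. Compound 3 (`COc1ccc(N/C(=N/[C@@H]2c3cc(C#N)ccc3OC(C)(C)[C@H]2O)NC#N)cc1`) gives 32500 nM, the higher of the two actual numbers, and the comparison between them is a 54-fold higher number from compound 1 to compound 3 (1.73 log units; beyond the scatter). Compound 2 (`CC1(C)Oc2ccc(C#N)cc2[C@@H](/N=C(\NC#N)Nc2ccc(C(=O)O)cc2)[C@@H]1O`) is reported only as a limit of the assay, > 100000 nM.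

The next compound, compound 4 (`Cc1ccc(N/C(=N/[C@@H]2c3cc(C#N)ccc3OC(C)(C)[C@H]2O)NC#N)cc1`), has methyl in place of methoxy on an aromatic carbon, para to a large group: methyl in place of methoxy on an aromatic carbon. For the measured compounds named here, no measured step makes this exact exchange. The closest is an at least 3.0-fold lower number from compound 2 to compound 3 (0.48 log units; beyond the scatter), which also swaps one group for another on an aromatic carbon, and its size is bounded rather than known, as the limit of > 100000 nM in this assay, at which 1 of the 3 values shown sits, shows. The larger steps, an at least 160-fold higher number from compound 1 to compound 2 (2.22 log units; beyond the scatter) and a 54-fold higher number from compound 1 to compound 3 (1.73 log units; beyond the scatter), both replace the chlorophenyl group, so they bear less directly on this exchange. In this assay, a modest move towards a lower number is therefore expected, though it may not clear the scatter by much. The estimated change is a 2.3-fold lower number from compound 3 to compound 4 (0.37 log units; beyond the scatter). For compound 4 the expected value is 14000 nM, with an estimated range from 3000 nM to 50000 nM.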

Compound 4, half-maximal inhibitory concentration: 2700 nM
The estimate for compound 4 lay 5.2-fold (0.71 log units) above the measured number; measured number outside the range, below it.
By their numbers in this assay, from the lowest: compound 1; then compound 4; then compound 3. At a limit, above all of these: compound 2.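

In this assay, the exchange on this aromatic carbon, para to a large group, is far from minor: a 12-fold lower number from compound 3 to compound 4 (1.08 log units; beyond the scatter), which gives the first exact size for a swap between two groups at this place. A group at this place also need not carry the large penalty seen with 4-methoxyphenyl and 4-carboxyphenyl, since the 4-methylphenyl group stays much nearer the 3-chlorophenyl group, with a 4.5-fold higher number from compound 1 to compound 4 (0.65 log units; beyond the scatter), although compound 1 still keeps the lower number. The value of compound 2 is a limit, so the step to methyl, an at least 37-fold lower number from compound 2 to compound 4 (1.56 log units; beyond the scatter), is bounded and its exact size is unknown: the limit of > 100000 nM in this assay, at which 1 of the 4 values shown sits.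

Going by these compounds, whether the remaining gap to compound 1 follows from the chlorine or from where it sits remains open, and a 4-chlorophenyl or 3-methylphenyl group would separate the two. On these data alone, it is also open how other groups at this place, such as an ethyl group, an amine or a hydroxyl, would fall relative to methyl and methoxy.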